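Hydroxymethyl to formyl on the chain of compound 2

This account rests on a few compounds, and the source may have more. Where it says the series, first, only, none or still open, it means among the compounds named here.

Measured so far:
compound 1 `Cn1c(Cc2nn(CCCO[Si](C)(C)C(C)(C)C)c(=O)c3ccccc23)nnc1SCCCCCCCC(=O)Nc1ccc(Cl)cc1Cl` gives > 30000 nM (a limit of the assay).
compound 2 `Cn1c(Cc2nn(CCCO)c(=O)c3ccccc23)nnc1SCCCCCCCC(=O)Nc1ccc(Cl)cc1Cl` gives > 30000 nM (a limit of the assay).

In an assay on 32D cells for inhibition of interleukin-15 (Mus musculus), read by resazurin assay, with stated times of 30 min and 2.5 days, in the presence of a further agent that is not named here (on this read-out higher numbers stand for weaker inhibition and lower numbers for stronger inhibition), compound 1 reaches only a limit, > 30000 nM. Compound 2 likewise reaches only a limit, > 30000 nM. The step that the two limits leave unreadable from compound 1 to compound 2 is therefore unreadable, since both values sit at the limit of > 30000 nM in this assay, at which 2 of the 2 values shown sit. Compound 2 thus stands at the limit, with no number of its own.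

Compound 3 `Cn1c(Cc2nn(CCC=O)c(=O)c3ccccc23)nnc1SCCCCCCCC(=O)Nc1ccc(Cl)cc1Cl` differs from compound 2 by formyl in place of hydroxymethyl on a saturated chain carbon, two bonds along the chain from an aromatic nitrogen. Among the compounds with values here, no measured step bears on this change; the one step available, from compound 1 to compound 2, gives no readable size. With nothing in the shown steps to suggest a move off the limit, compound 3 is expected to stay there as well. The estimate for compound 3 is 30000 nM, range 10000 nM to 100000 nM. The step of a number no higher from compound 2 to compound 3 (the limit leaves the size open) is expected to be none beyond the scatter, most likely reported again as a limit.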

Compound 3, half-maximal inhibitory concentration: 11700 nM
Compound 3: the middle estimate sits 2.6-fold (0.41 log units) above what was measured; the measured number falls inside the stated range.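

In this assay, within the data shown here, compound 3 is the first of the series with a number rather than a limit, 11700 nM, so a change on this chain, two bonds along from an aromatic nitrogen, can now be read. Formyl in place of hydroxymethyl gives an at least 2.5-fold lower number from compound 2 to compound 3 (0.40 log units; beyond the scatter), and the shorter group in place of the larger silicon-bearing group gives an at least 2.5-fold lower number from compound 1 to compound 3 (0.40 log units; beyond the scatter); the true size of both steps stays open, as each starts from a limit. The step from compound 1 to compound 2 remains unreadable: the limit of > 30000 nM in this assay, at which 2 of the 3 values shown sit.

The compounds shown do not tell whether this response is particular to formyl or would extend to other groups at the chain end. A carboxylic acid, an amine or a longer chain carrying the formyl group at this place would test that.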